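The compounds below may be only part of what the source reports. "The series", "measured", "known", "first", "only" and "open" are said of these compounds alone.

Measured in an in vitro ADME assay on microsomes from Gut (Homo sapiens) for metabolic stability, in the presence of a further agent that is not named here; on this read-out lower numbers stand for slow clearance and higher numbers for fast clearance:
- Compound 1 `CCOc1ccc(OC(F)(F)F)cc1Cn1c(C(=O)NCC(C)(C)CO)cc2cc(C#N)ccc21` gives 103 mL.min-1.g-1
- Compound 2 `COc1ccc(C(F)(F)F)cc1Cn1c(C(=O)NCC2(CO)CC2)cc2cc(C#N)ccc21` gives 49 mL.min-1.g-1
- Compound 3 `CC(C)(O)CCNC(=O)c1cc2cc(C#N)ccc2n1Cc1cccc(OC(F)(F)F)c1` gives 9 mL.min-1.g-1

Compound 3 has the lowest number of the three, and its gaps to compound 2 and compound 1 both lie beyond the usual scatter. Compound 4 `CC(O)C1(CNC(=O)c2cc3cc(C#N)ccc3n2Cc2cccc(OC(F)(F)F)c2)CCCC1` alters only the group on the amide side chain: a group of 8 heavy atoms (7 carbon, 1 oxygen; one five-membered non-aromatic ring of carbon only) in place of a group of 5 heavy atoms (4 carbon, 1 oxygen; no ring), on a saturated chain carbon bound to an amide-type nitrogen. For the measured compounds named here, no measured pair differs in just one place, so the data show no direct precedent for this change. Compound 1 and compound 2 differ from compound 3 in several places, which makes them only a loose guide. A moderate rise in this assay is expected, beyond the scatter, since compound 3 at 9 mL.min-1.g-1 leaves more room upward than downward. The expected change is a 3.1-fold higher number from compound 3 to compound 4 (0.49 log units; beyond the scatter). For compound 4 the estimated value is 28 mL.min-1.g-1, with an expected range of 11 mL.min-1.g-1 to 75 mL.min-1.g-1.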

Compound 4, intrinsic clearance in microsomes: < 6 mL.min-1.g-1
Compound 4: no number, only a limit; the forecaster's own chance of this, stated with the estimate: 5%; middle value at least 4.6-fold (0.66 log units) from the limit.
By their numbers in this assay, from the lowest: compound 3; then compound 2; then compound 1. At a limit, below all of these: compound 4.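

Compound 4 gives a limit rather than a number in this assay: the limit of < 6 mL.min-1.g-1 in this assay, at which 1 of the 4 values shown sits. Placing the larger group with its five-membered carbon ring on a saturated chain carbon bound to an amide-type nitrogen, in place of 2-hydroxy-2-methylpropyl, gives an at least 1.5-fold lower number from compound 3 to compound 4 (0.17 log units; that floor lies within the scatter), so no rise appears, though a real fall is not established. For the compounds shown here, this is the first direct reading of a change at this place, since no earlier pair differed in one place only. On these data alone, how far compound 4 lies past its limit stays open. So does whether an amine or a carboxylic acid on this chain would keep the read-out as low.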